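The source may report more compounds than this note shows. Statements on the series, on what has been measured and on what is new or still open speak of the compounds shown alone.

Compound 1 `Cn1nc(Cc2nnc(SCC(=O)Nc3ccc(Cl)cc3Cl)n2CCC(=O)O)c2ccccc2c1=O`: a limit, > 30000 nM
Compound 2 `Cn1nc(Cc2nnc(SCCCCCCCC(=O)Nc3ccc(Cl)cc3Cl)n2CCCO)c2ccccc2c1=O`: a limit, > 30000 nM
Compound 3 `Cn1c(Cc2nn(CCC3OCCO3)c(=O)c3ccccc23)nnc1SCC(=O)Nc1ccc(Cl)cc1Cl`: a limit, > 30000 nM

In an assay on 32D cells for inhibition of interleukin-15 (Mus musculus), read by resazurin assay, with stated times of 30 min and 2.5 days, in the presence of a further agent that is not named here (on this read-out lower numbers stand for stronger inhibition and higher numbers for weaker inhibition), compound 3 gives only a limit, > 30000 nM. Every measured value sits at that same limit (the limit of > 30000 nM in this assay, at which 3 of the 3 values shown sit), so compound 3 cannot be placed above or below the others; none of the three gives a number. Compound 4 `Cn1c(Cc2nn(CCC=O)c(=O)c3ccccc23)nnc1SCC(=O)Nc1ccc(Cl)cc1Cl` differs from compound 3 in one place: formyl in place of 1,3-dioxolan-2-yl on a saturated chain carbon, two bonds along the chain from an aromatic nitrogen. Within the data shown here, no step between measured compounds is available to gauge this change. Since compound 3 gives > 30000 nM, compound 4 is expected to stay at the limit as well. The step is estimated as a number no higher from compound 3 to compound 4 (the limit leaves the size open), none beyond the scatter. For compound 4 the estimate in this assay is 30000 nM, with a range from 10000 nM to 100000 nM.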

Compound 4, half-maximal inhibitory concentration: 30000 nM
Estimate against measurement, compound 4: no gap at the digits printed, and the stated range covers the measured number.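

In this assay compound 4 gives 30000 nM, the only actual number among the compounds shown. Going from 1,3-dioxolan-2-yl to formyl on this saturated chain carbon gives a number no higher from compound 3 to compound 4 (the limit leaves the size open), so this change brings the first readable value at this position, although the size of the step cannot be read. The other values offer no number for comparison: the limit of > 30000 nM in this assay, at which 3 of the 4 values shown sit.

The compounds shown leave open whether an amine or a longer chain at this place would give a lower number than compound 4.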